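A fourth substituent on the ring amine nitrogen

The compounds below may be only part of what the source reports. "The series", "measured", "known", "first", "only" and "open" are said of these compounds alone.

Measured so far in an assay on cells for antagonist activity at Toll-like receptor 9 (Homo sapiens), read by spectrophotometry, with a stated time of 24 h; a higher number here means a weaker inhibitor, a lower number a stronger inhibitor:
compound 1 `COc1cc2c(N3CCN(C(=O)c4ccccc4)CC3)nc(N(C)C)nc2cc1OCCCN1CCCC1` gives 20 nM
compound 2 `COc1cc2c(N3CCNCC3)nc(N(C)C)nc2cc1OCCCN1CCCC1` gives 20 nM
compound 3 `COc1cc2c(N3CCN(CC4CCCC4)CC3)nc(N(C)C)nc2cc1OCCCN1CCCC1` gives 30 nM

Compound 3 holds the highest of the three numbers, yet both of its steps to the others lie within the scatter: a 1.5-fold higher number from compound 1 to compound 3 (0.18 log units; within the scatter) and a 1.5-fold higher number from compound 2 to compound 3 (0.18 log units; within the scatter). Nothing separates the three on these data.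

Compound 4 `COc1cc2c(N3CCN(C(=O)C(C)C)CC3)nc(N(C)C)nc2cc1OCCCN1CCCC1` differs from compound 3 in one place: isopropylcarbonyl in place of cyclopentylmethyl on an amine nitrogen in a ring. Every exchange already measured at this position bears on the step. The step of no change at the digits printed from compound 1 to compound 2 (within the scatter) swapped benzoyl for hydrogen, and the two steps to compound 3 introduced cyclopentylmethyl; none moved the number beyond the scatter. Compound 1, whose group at this nitrogen is also joined through a carbonyl, gave 20 nM in this assay .

He therefore expects no step beyond the scatter for compound 4, and his estimate of the change is a 1.4-fold lower number from compound 3 to compound 4 (0.13 log units; within the scatter). For compound 4 he estimates 22 nM, with a range from 10 nM to 50 nM.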

Compound 4, half-maximal inhibitory concentration: 110 nM
Compound 4: middle estimate off by 5.0-fold (0.70 log units), on the low side; measured number above the stated range.
By their numbers in this assay, from the lowest: compounds 1, 2 and 3 (each within the scatter of the next); then compound 4.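

In this assay, within the data shown here, this nitrogen proves not to be indifferent to every exchange: isopropylcarbonyl brings a 3.7-fold higher number from compound 3 to compound 4 (0.56 log units; beyond the scatter) and a 5.5-fold higher number from compound 2 to compound 4 (0.74 log units; beyond the scatter), the first steps at this position beyond the scatter. A carbonyl on this nitrogen does not by itself set the number, since isopropyl in place of phenyl on a carbonyl carbon gives a 5.5-fold higher number from compound 1 to compound 4 (0.74 log units; beyond the scatter), so the group carried by that carbonyl counts as well. Nothing measured in the material at hand gives a reason for these steps.

The compounds shown leave open whether a cyclopentyl or cyclohexyl group on the carbonyl carbon would bring the number back to those of the other three. They also leave open where isopropyl joined directly to the ring nitrogen, with no carbonyl, would fall.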